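The source may report more compounds than this note shows. Statements on the series, on what has been measured and on what is new or still open speak of the compounds shown alone.

Compound 1 `CC(C)c1onc(-c2c(Cl)cccc2Cl)c1COc1ccc(NCc2ccc(C(=O)O)cc2)c(C(F)(F)F)n1`: 101 nM
Compound 2 `CC(C)c1onc(-c2c(Cl)cccc2Cl)c1COc1ccc(N(C)Cc2ccc(CCC(=O)O)cc2)c(C(F)(F)F)n1`: 16 nM

In a functional assay on HEK293 cells for agonist activity at Bile acid receptor (Homo sapiens), read by a luciferase reporter (on this read-out higher numbers stand for an effect only at larger amounts of compound and lower numbers for an effect already at smaller amounts), compound 2 gives 16 nM, the lowest of the two numbers, while compound 1 gives 101 nM, a gap beyond the scatter. Compound 3 `CC(C)c1onc(-c2c(Cl)cccc2Cl)c1COc1ccc(N(C)Cc2ccc(OCC(=O)O)cc2)c(C(F)(F)F)n1` differs from compound 2 by carboxymethoxy in place of 2-carboxyethyl on an aromatic carbon, a chain of the same length. Among the compounds with values here, no measured pair shows this change, so the step from compound 2 to compound 3 in this assay is expected to be small, within or only just beyond the scatter, if anything toward a higher number. Compound 3 is therefore estimated at 25 nM, with a range from 8 nM to 80 nM. That expectation amounts to a step of a 1.6-fold higher number from compound 2 to compound 3 (0.19 log units; within the scatter).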

Compound 3, half-maximal effective concentration: 19 nM
For compound 3 the middle estimate is 1.3-fold (0.12 log units) above the measured one, and the stated range covers the measured number.
By their numbers in this assay, from the lowest: compounds 2 and 3 (each within the scatter of the next); then compound 1.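

In this assay, carboxymethoxy in place of 2-carboxyethyl on this aromatic carbon, para to a large group, gives a 1.2-fold higher number from compound 2 to compound 3 (0.07 log units; within the scatter), so the assay does not tell these two groups apart at this position. Within the data shown here, this is the first pair differing in one place, and it shows that the position accepts this exchange of chain without a change beyond the scatter. Nothing at hand accounts for the two groups reading alike. Still open, as far as these compounds go, is how a longer chain such as 3-carboxypropyl would read at this position, and whether a tetrazole could stand in for the carboxylic acid.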